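Carboxy to carbamoyl: from compound 3 to compound 4

This account rests on a few compounds, and the source may have more. Where it says the series, first, only, none or still open, it means among the compounds named here.

Compound 1 `COc1ccc(C(C)=O)cc1COc1cccc(C)c1`: 24000 nM
Compound 2 `CCc1ccc(OC)c(COc2ccc(Cl)c(C)c2)c1`: 43000 nM
Compound 3 `COc1ccc(C(=O)O)cc1COc1ccc(Cl)c(C)c1`: > 50000 nM

In an ADME assay on HCT-116 cells (Homo sapiens) for antiproliferative activity (on this read-out higher numbers stand for weaker inhibition and lower numbers for stronger inhibition), compound 3 gives > 50000 nM, which is a limit of the assay and not a number.

Compound 4 `COc1ccc(C(N)=O)cc1COc1ccc(Cl)c(C)c1` differs from compound 3 in one place: amino in place of hydroxy on a carbonyl carbon. This is amino in place of hydroxy on a carbonyl carbon, or carboxy to carbamoyl.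

Within the data shown here, only one measured step touches this group: an at least 1.1-fold higher number from compound 2 to compound 3 (0.06 log units; that floor lies within the scatter). It is a different exchange, carboxy in place of ethyl on an aromatic carbon, and it gives only a floor, so it sets no size for the new step.

Without a carboxy group, compound 1 gives 24000 nM and compound 2 gives 43000 nM, so a number in that region is expected for compound 4. A small move toward lower numbers is therefore expected, perhaps none beyond the scatter, and another limit is possible.

The expected step is an at least 1.4-fold lower number from compound 3 to compound 4 (0.15 log units; that floor lies within the scatter).

The estimate for compound 4 is 35000 nM, with an expected range from 12000 nM to 80000 nM.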

Compound 4, half-maximal inhibitory concentration: > 50000 nM
Compound 4: no number, only a limit (the forecaster's own chance of this, stated with the estimate: 45%); middle value at least 1.4-fold (0.15 log units) away from the limit.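

In this assay, compound 4 sits at a limit of the assay and not at a number, so carbamoyl gives no readable value where carboxy gave none in compound 3, and the step between these two compounds cannot be read. Among these compounds, the only step that can be read is an at least 1.1-fold higher number from compound 2 to compound 4 (0.06 log units; that floor lies within the scatter), and this is a floor, so it sets no size for carbamoyl in place of ethyl. A limit on this aromatic carbon therefore comes with carbamoyl as well as with carboxy, and the two groups cannot be ranked: the limit of > 50000 nM in this assay, at which 2 of the 4 values shown sit.

Going by these compounds, how far compound 3 and compound 4 lie beyond that limit stays open. So does whether a nitrile or an amine on the same carbon, with the rest of the structure unchanged, would give a measurable number.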